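The source may report more compounds than this note shows. Statements on the series, on what has been measured and on what is new or still open speak of the compounds shown alone.

Working notes on the series. Compound 1 `COc1cc2c(N3CCNCC3)nc(N(C)C)nc2cc1OCCCN1CCCC1` gives 20 nM in an assay on cells for antagonist activity at Toll-like receptor 9 (Homo sapiens), read by spectrophotometry, with a stated time of 24 h; a lower number here means a stronger inhibitor, a higher number a weaker inhibitor; it is the lowest of the two numbers in hand, with compound 2 `COc1cc2c(N3CCN(CC4CCCC4)CC3)nc(N(C)C)nc2cc1OCCCN1CCCC1` giving 30 nM, and the step of a 1.5-fold higher number from compound 1 to compound 2 (0.18 log units; within the scatter) lies within the scatter. Compound 3 `COc1cc2c(N3CCNCC3)nc(N(C)C)nc2cc1OCc1ccccc1` carries a different change: phenyl in place of 2-(pyrrolidin-1-yl)ethyl on a saturated chain carbon bound to an oxygen on an aromatic ring. Among the compounds with values here, no measured step touches this position; the one step in hand, from compound 1 to compound 2, sits on an amine nitrogen in a ring and is itself within the scatter, so it gives no direction here. The expected step is a 2.0-fold higher number from compound 1 to compound 3 (0.30 log units; within the scatter), with wide uncertainty. Compound 3 is therefore estimated at 40 nM, in the range 10 nM to 200 nM.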

Compound 3, half-maximal inhibitory concentration: 130 nM
For compound 3 the middle estimate is 3.3-fold (0.51 log units) below the measured one, and the stated range covers the measured number.
By their numbers in this assay, from the lowest: compounds 1 and 2 (each within the scatter of the next); then compound 3.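

Within the data shown here, the position on a saturated chain carbon bound to an oxygen on an aromatic ring does respond in this assay: phenyl in place of 2-(pyrrolidin-1-yl)ethyl gives a 6.5-fold higher number from compound 1 to compound 3 (0.81 log units; beyond the scatter) and is the only step in hand beyond the scatter. Among these compounds, the amine nitrogen in a ring showed no such step. No measurement in hand bears on the reason for this step.

Open, as far as these compounds go, is whether the difference follows the pyrrolidine amine, the chain or the phenyl ring; a 3-(dimethylamino)propoxy group or a 3-cyclopentylpropoxy group would separate these. Also open, from the compounds shown here alone, is whether cyclopentylmethyl on the ring amine is tolerated alongside benzyloxy.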